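Growth inhibition notes: tert-butyl in place of ethyl

This account rests on a few compounds, and the source may have more. Where it says the series, first, only, none or still open, it means among the compounds named here.

Values in a functional assay on CH1 cells (Homo sapiens) for inhibition, read by sulforhodamine B assay, with a stated time of 96 h; a lower number here means a stronger inhibitor of growth, a higher number a weaker inhibitor of growth:
Compound 1 `CC[C@@H](Nc1nc(NCc2ccccn2)c2ncn(C(C)C)c2n1)C(C)(C)O`: > 50000 nM (a limit, not a number)
Compound 2 `CC[C@@H](Nc1nc(NCc2ccccn2)c2ncn(C(C)C)c2n1)C(C)O`: 20000 nM
Compound 3 `CCC(O)[C@@H](CC)Nc1nc(NCc2ccccn2)c2ncn(C(C)C)c2n1`: 27000 nM
Compound 4 `CC[C@@H](Nc1nc(NCc2ccccn2)c2ncn(C(C)C)c2n1)C(O)C(C)(C)C`: not yet measured

Compound 3 stands level with compound 2, with a 1.4-fold higher number from compound 2 to compound 3 (0.13 log units; within the scatter). Its distance from compound 1 is known only as a floor, an at least 1.8-fold lower number from compound 1 to compound 3 (0.26 log units; that floor lies within the scatter).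

The next structure, compound 4, differs from compound 3 by tert-butyl in place of ethyl on a saturated chain carbon bound to an oxygen on a saturated carbon and a saturated chain carbon. This places tert-butyl in place of ethyl on a saturated chain carbon bound to an oxygen on a saturated carbon and a saturated chain carbon. Among the compounds with values here, no measured step makes this exact change, but two bear on it. The closer one is a 1.4-fold higher number from compound 2 to compound 3 (0.13 log units; within the scatter), where methyl in place of hydrogen left the reading within the scatter. The other is an at least 2.5-fold lower number from compound 1 to compound 2 (0.39 log units; beyond the scatter), which is beyond the scatter and shows compound 1, the compound with the extra methyl, on the weaker side. Neither step shows added carbon lowering the number in this assay, so a modest move towards a higher number is expected. The expected step is a 1.3-fold higher number from compound 3 to compound 4 (0.11 log units; within the scatter), and a reading that returns only a limit remains possible. For compound 4 the estimate is 35000 nM, with an expected range of 15000 nM to 70000 nM.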

Compound 4, concentration for 50% growth inhibition: 34000 nM
Compound 4: middle estimate off by 1.0-fold (0.01 log units), on the high side; low and high end bracket the measured number.
By their numbers in this assay, from the lowest: compounds 2, 3 and 4 (each within the scatter of the next). At a limit, above all of these: compound 1.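

Within the data shown here, at the saturated chain carbon bound to an oxygen on a saturated carbon and a saturated chain carbon, the earlier compounds tested only a small change, whereas tert-butyl is a much larger replacement, and in this assay the step is still a 1.3-fold higher number from compound 3 to compound 4 (0.10 log units; within the scatter). Measured from the methyl member, the step is a 1.7-fold higher number from compound 2 to compound 4 (0.23 log units; within the scatter), so methyl, ethyl and tert-butyl at this place cannot be told apart in this assay, and the size of this group has not yet shown any reading effect across these compounds. The comparison with the remaining compound is weaker, with the step being an at least 1.4-fold lower number from compound 1 to compound 4 (0.16 log units; that floor lies within the scatter), so compound 4 is not clearly separated from it, and the value for compound 1 is a limit, not a number: the limit of > 50000 nM in this assay, at which 1 of the 4 values shown sits.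

Going by these compounds, whether a phenyl ring or a longer chain at this place would move the number beyond the scatter stays open, and so does whether an amine in place of the hydroxyl oxygen would do so. The compounds shown also leave open whether any member of this set can be separated from the others in this assay.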